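Towards compound 3: a benzylic amine in place of the chain

The compounds below may be only part of what the source reports. "The series", "measured", "known", "first", "only" and "open" are said of these compounds alone.

Two compounds of this series have been examined in a functional assay on cells for agonist activity at C-X-C chemokine receptor type 4 (Homo sapiens), read by fluorescence and calcium flux, with a stated time of 90 s; a higher number here means that more compound is needed for the effect, a lower number that less compound is needed. Compound 1, `c1ccc(CNCCCCN(C[C@H]2Cc3ccccc3CN2)[C@H]2CCCc3cccnc32)cc1`, gives in this assay > 30000 nM, which is a limit of the assay and not a number. Compound 2, `c1ccc2c(c1)CN[C@@H](CN(CCCCNC1CCOCC1)[C@H]1CCCc3cccnc31)C2`, likewise gives in this assay > 30000 nM, again a limit rather than a number. The step from compound 1 to compound 2 in this assay, a step that the two limits leave unreadable from compound 1 to compound 2, therefore cannot be read, since both ends sit at a limit; this is the whole of the evidence, summed up as the limit of > 30000 nM in this assay, at which 2 of the 2 values shown sit. Compound 2 thus stands at the limit of this assay, with no number of its own.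

Compound 3, `NCc1cccc(CN(C[C@H]2Cc3ccccc3CN2)[C@H]2CCCc3cccnc32)c1`, differs from compound 2 by one change: 3-(aminomethyl)phenyl in place of 3-((oxan-4-yl)amino)propyl on a saturated chain carbon bound to an amine nitrogen. Among the compounds with values here, no measured step bears on this change, because the only step available, from compound 1 to compound 2, is unreadable at both ends. With both measured compounds at the limit, the step from compound 2 to compound 3 in this assay is expected to be a number no higher from compound 2 to compound 3 (the limit leaves the size open), that is, nothing that can be read beyond the limit. Compound 3 is accordingly expected to give in this assay about 30000 nM, within a range from 8000 nM to 100000 nM, most probably again as a limit.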

Compound 3, half-maximal effective concentration: > 30000 nM
Compound 3 was reported as a limit (the forecaster's own chance of this, stated with the estimate: 80%); the middle value sits exactly at the limit.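

No step among compound 1, compound 2 and compound 3 can be read, since each result is a limit of the assay and not a number: the limit of > 30000 nM in this assay, at which 3 of the 3 values shown sit.

The compounds shown leave open how much of each would be needed for the effect, and whether any of the changes between them alters that amount.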